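This account rests on a few compounds, and the source may have more. Where it says the series, first, only, none or still open, it means among the compounds named here.

Three compounds built on the shared core of compound 1 `COC(=O)[C@H](CCSC)NC(=O)c1ccc(NCc2cncn2Cc2ccccc2C)cc1-c1ccccc1` have been examined in a functional assay on NIH3T3 cells (Mus musculus); a higher number here means that more compound is needed for the effect, a lower number that less compound is needed. In this assay compound 1 gives > 10 uM, which is a limit of the assay rather than a number. Compound 2 `COC(=O)[C@H](CCSC)NC(=O)c1ccc(NCc2cncn2Cc2cccc([N+](=O)[O-])c2)cc1-c1ccccc1` carries a 3-nitrophenyl in place of the 2-methylphenyl, and in this assay compound 2 gives > 10 uM, again a limit. Compound 3 `COC(=O)[C@H](CCSC)NC(=O)c1ccc(NCc2cncn2Cc2ccc(C#N)cc2)cc1-c1ccccc1` carries a 4-cyanophenyl, and in this assay compound 3 gives > 10 uM, also a limit. Compound 3 therefore stands at the same limit as the two other values shown, with no number of its own. The steps a step that the two limits leave unreadable from compound 1 to compound 2, a step that the two limits leave unreadable from compound 1 to compound 3 and a step that the two limits leave unreadable from compound 2 to compound 3 cannot be sized, because of the limit of > 10 uM in this assay, at which 3 of the 3 values shown sit. Compound 4 `COC(=O)[C@H](CCSC)NC(=O)c1ccc(NCc2cncn2Cc2ccccc2C#N)cc1-c1ccccc1` is the next member; its change from compound 3 is 2-cyanophenyl in place of 4-cyanophenyl on a saturated chain carbon bound to an aromatic nitrogen. All three measured steps bear on this change, since each swaps the group on the same saturated chain carbon bound to an aromatic nitrogen, yet none of them has a readable size. There is thus no basis to expect a step beyond the scatter in this assay, and compound 4 is expected to sit near the limit again. The step from compound 3 to compound 4 is estimated as a step that the limit leaves unreadable from compound 3 to compound 4. For compound 4 the value in this assay is estimated at 20 uM, within a range of 6 uM to 80 uM, with the likeliest outcome being that only a limit is reported.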

Compound 4, concentration for half-maximal effect: > 10 uM
Compound 4 ended at the assay's limit; the forecaster's own chance of this, stated with the estimate: 80%; the middle value lies beyond the limit too.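

In this assay compound 4 gives > 10 uM, which is a limit and not a number. No new step can be read between compound 4 and compound 1, compound 2 or compound 3: the limit of > 10 uM in this assay, at which 4 of the 4 values shown sit. The compounds shown leave open whether the group on the saturated chain carbon bound to an aromatic nitrogen changes the concentration needed at all.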